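The source may report more compounds than this note shows. Statements on the series, on what has been measured and on what is new or still open speak of the compounds shown alone.

Measured so far in a physicochemical assay for solubility, read by chemiluminescence; a lower number here means a less soluble compound, a higher number a more soluble compound:
- Compound 1 `Cn1ccc(C(=O)N(CC(=O)Nc2cc(F)cc(F)c2)C2CCCCC2)n1`: 163 ug/mL
- Compound 2 `O=C(CN(C(=O)c1ccc(-c2ccccn2)cc1)C1CCCCC1)Nc1cc(F)cc(F)c1`: 6 ug/mL
- Compound 3 `O=C(CN(C(=O)c1ccc(-c2ccccn2)cc1)C1CCCOC1)Nc1cc(F)cc(F)c1`: 56 ug/mL

Compound 3, at 56 ug/mL, holds the middle place of the three. Compound 1 reads higher, at 163 ug/mL, and compound 2 reads lower, at 6 ug/mL. Both gaps lie beyond the usual scatter.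

The unmeasured compound 4 `O=C(CN(CC1CCC1)C(=O)c1ccc(-c2ccccn2)cc1)Nc1cc(F)cc(F)c1` differs from compound 3 in one group on an amide-type nitrogen, with cyclobutylmethyl in place of oxan-3-yl on an amide-type nitrogen.

Going by the values given here, one measured step bears on this change: a 9.3-fold higher number from compound 2 to compound 3 (0.97 log units; beyond the scatter). It is modest but beyond the scatter, and it came with oxan-3-yl taking the place of cyclohexyl on an amide-type nitrogen. Compound 4 loses oxan-3-yl again and, like compound 2, carries a group of carbon only there. Cyclobutylmethyl is not cyclohexyl, however, and no measured compound carries it, so this single step gives only a loose guide.

A fall of similar or somewhat smaller size, beyond the scatter, therefore seems likely. The expected step is a 5.1-fold lower number from compound 3 to compound 4 (0.71 log units; beyond the scatter).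

Compound 4 is estimated at 11 ug/mL, with an expected range from 4 ug/mL to 30 ug/mL.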

Compound 4, solubility: 7 ug/mL
The estimate for compound 4 lay 1.6-fold (0.20 log units) above the measured number; the range from low to high includes it.
By their numbers in this assay, from the lowest: compounds 2 and 4 (each within the scatter of the next); then compound 3; then compound 1.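

In this assay, this change gives an 8.0-fold lower number from compound 3 to compound 4 (0.90 log units; beyond the scatter), so a second carbon-only group on the amide-type nitrogen now reads well under the oxan-3-yl compound, and the high reading of compound 3 no longer rests on the comparison with cyclohexyl alone. Cyclobutylmethyl in place of cyclohexyl gives a 1.2-fold higher number from compound 2 to compound 4 (0.07 log units; within the scatter), so these two carbon-only groups read alike here, and among the three compounds that differ only at this place, the higher number goes with oxan-3-yl, with none going against that pattern. Nothing measured here explains why compound 3 stands apart from the two carbon-only compounds.

The compounds shown leave open how an amine, a carboxylic acid or a longer chain holding an ether oxygen would read on this nitrogen, and so whether the higher number belongs to oxan-3-yl alone or extends to other groups with a hetero atom. Also open, from the compounds shown here alone, is whether the same swaps would give similar steps on the core of compound 1, which carries cyclohexyl at this place.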